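Shortening an alkyl chain on a PLK2 inhibitor series

This account rests on a few compounds, and the source may have more. Where it says the series, first, only, none or still open, it means among the compounds named here.

Compound 1 `CC[C@@H]1C(=O)N(C)c2cnc(Nc3ccc(S(=O)(=O)NC)cc3)nc2N1C1CCCC1`: 3.4 nM
Compound 2 `CCCNS(=O)(=O)c1ccc(Nc2ncc3c(n2)N(C2CCCC2)[C@H](CC)C(=O)N3C)cc1`: 17.8 nM
Compound 3 `CCCCNC(=O)c1ccc2c(ccn2-c2ncc3c(n2)N(c2ccn(C)n2)C(CC)C(=O)N3C)c1`: 159 nM

In an assay for inhibition of serine/threonine-protein kinase PLK2 (Homo sapiens), read by FRET and Z'-LYTE, with a stated time of 1 h (on this read-out lower numbers stand for stronger inhibition and higher numbers for weaker inhibition), compound 1 gives 3.4 nM and compound 2 gives 17.8 nM. The two differ by hydrogen in place of ethyl on a saturated chain carbon bound to a sulfonamide nitrogen, and that step reads a 5.2-fold lower number from compound 2 to compound 1 (0.72 log units; beyond the scatter). Compound 3 gives 159 nM; how its core differs from that of compound 2 is not broken down here. Compound 4 `CCNC(=O)c1ccc2c(ccn2-c2ncc3c(n2)N(c2ccn(C)n2)C(CC)C(=O)N3C)c1` is not yet measured; it differs from compound 3 by hydrogen in place of ethyl on a saturated chain carbon, two bonds along the chain from an amide-type nitrogen. This is the same kind of change as from compound 2 to compound 1, but the surroundings are not identical: there the carbon was bound to a sulfonamide nitrogen, here it is two bonds along the chain from an amide-type nitrogen, and the cores differ. Resting on a 5.2-fold lower number from compound 2 to compound 1 (0.72 log units; beyond the scatter) for compound 1, a smaller step is expected for compound 4, a 1.8-fold lower number from compound 3 to compound 4 (0.25 log units; within the scatter), estimated at 90 nM, within 30 nM to 250 nM.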

Compound 4, half-maximal inhibitory concentration: 243 nM
Compound 4: middle estimate off by 2.7-fold (0.43 log units), on the low side, within the range that was stated.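

In this assay, among these compounds, the shortening reads a 1.5-fold higher number from compound 3 to compound 4 (0.18 log units; within the scatter), so on this core it gives no step that can be told apart from repeat measurements. Set beside the earlier step, the result does not match: the same change on two cores in this assay, a 5.2-fold lower number (0.72 log units; beyond the scatter) from compound 2 to compound 1 and a 1.5-fold higher number (0.18 log units; within the scatter) from compound 3 to compound 4, 8.0-fold (0.90 log units) apart, beyond the scatter of two such steps. This shows that the step seen from compound 2 to compound 1 did not carry over to the pair of compound 3 and compound 4, but with a single pair on each core it does not show why, nor does it give a rule for the series.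

The compounds shown leave open whether the difference goes with the core or with the sulfonamide and amide-type nitrogens, as no pair separates the two. They also leave open how a longer chain or a carboxylic acid in that place would read on either core.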